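The source may report more compounds than this note shows. Statements on the series, on what has been measured and on what is new or still open speak of the compounds shown alone.

The compounds measured so far:

Compound 1 `CN(C)C(=O)C1CCN(c2nc(-c3cc(F)c(Cl)cc3F)nc3c2CS(=O)(=O)C3)CC1`; in a physicochemical assay for solubility, with a stated time of 20 h, at pH 6.8 (a lower number here means a less soluble compound, a higher number a more soluble compound), compound 1 gives > 100000 nM, which is a limit of the assay and not a number.
Compound 2 `NC(=O)CC1CCN(c2nc(-c3cc(F)c(Cl)cc3F)nc3c2CS(=O)(=O)C3)CC1`; in this assay compound 2 gives 15000 nM.
Compound 3 `NC(=O)C1CCN(c2nc(-c3cc(F)c(Cl)cc3F)nc3c2CS(=O)(=O)C3)CC1`; in this assay compound 3 gives 40000 nM.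

Compound 3 holds the highest of the two plain numbers; the step from its nearest neighbour is a 2.7-fold higher number from compound 2 to compound 3 (0.43 log units; beyond the scatter). Compound 1 sits at the limit of > 100000 nM in this assay, at which 1 of the 3 values shown sits, so only a lower bound is known for it.

Compound 4 `NC(=O)CN1CCN(c2nc(-c3cc(F)c(Cl)cc3F)nc3c2CS(=O)(=O)C3)CC1` differs from compound 3 in one place: 4-(carbamoylmethyl)piperazin-1-yl in place of 4-carbamoylpiperidin-1-yl on an aromatic carbon. Among the compounds with values here, no measured step swaps the saturated ring itself. The closest guide is the amide change on that ring, a 2.7-fold higher number from compound 2 to compound 3 (0.43 log units; beyond the scatter), which was modest, while an at least 6.6-fold lower number from compound 1 to compound 2 (0.82 log units; beyond the scatter) and an at least 2.5-fold lower number from compound 1 to compound 3 (0.39 log units; beyond the scatter) only move away from a limit. A small to modest change is therefore expected for compound 4, with the direction uncertain, estimated as a 1.5-fold higher number from compound 3 to compound 4 (0.18 log units; within the scatter).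

Compound 4 is expected to give 60000 nM in this assay, within a range from 15000 nM to 200000 nM.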

Compound 4, solubility: > 100000 nM
Compound 4: no number, only a limit (the forecaster's own chance of this, stated with the estimate: 25%); middle value at least 1.6-fold (0.22 log units) away from the limit.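

Swapping 4-carbamoylpiperidin-1-yl for 4-(carbamoylmethyl)piperazin-1-yl on the aromatic carbon gives an at least 2.5-fold higher number from compound 3 to compound 4 (0.39 log units; beyond the scatter) in this assay, so a change to the saturated ring and its side chain can also move this number. The closer comparison keeps the carbamoylmethyl group and changes only the ring, with 4-(carbamoylmethyl)piperazin-1-yl in place of 4-(carbamoylmethyl)piperidin-1-yl, and it gives an at least 6.6-fold higher number from compound 2 to compound 4 (0.82 log units; beyond the scatter). Compound 4 gives a limit of the assay and not a number, so each step shows only the smallest possible size of the rise: the limit of > 100000 nM in this assay, at which 2 of the 4 values shown sit.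

Compound 1 and compound 4 cannot be placed in order against each other. Also open, on these data alone, is how the piperazin-1-yl compound would behave with a carboxylic acid or a longer chain in place of the carbamoylmethyl group.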